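The source may hold more compounds than are shown below. What is called first, only, known or untested is meant among the compounds shown, and "the series" means these compounds.

Measured so far in an ADME assay on Vero cells (Chlorocebus sabaeus) for cytotoxicity, read by sulforhodamine B assay, with a stated time of 3 days; on this read-out lower numbers stand for higher toxicity in this test and higher numbers for lower toxicity in this test:
- compound 1 `CC1=C(C(=O)Nc2ccc(Cl)cc2)C(c2ccccc2)C(C(=O)Nc2ccc(Cl)cc2)=C(C)N1` gives 15 ug/mL
- compound 2 `CC1=C(C(=O)Nc2ccc(Cl)cc2)C(c2cccc(Cl)c2)C(C(=O)Nc2ccc(Cl)cc2)=C(C)N1` gives 12 ug/mL

Compound 2 holds the lower of the two numbers, yet the gap to compound 1 is small: the step of a 1.3-fold lower number from compound 1 to compound 2 (0.10 log units; within the scatter), so the two compounds cannot be told apart in this assay.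

Compound 3 `CC1=C(C(=O)Nc2ccc(Cl)cc2)CC(C(=O)Nc2ccc(Cl)cc2)=C(C)N1` differs from compound 2 by hydrogen in place of 3-chlorophenyl on a saturated ring carbon. Within the data shown here, no measured step removes this group entirely; the only step available, from compound 1 to compound 2, concerns a substituent on that same aryl ring and was within the scatter. The loss of the whole ring is a larger change than any measured here, so the data give no firm direction. Compound 3 is therefore expected to stay near compound 2, with the step of a 1.7-fold higher number from compound 2 to compound 3 (0.22 log units; within the scatter) seen as a modest movement, and the estimate for compound 3 is 20 ug/mL, within 8 ug/mL to 50 ug/mL.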

Compound 3, half-maximal cytotoxic concentration: 40 ug/mL
Compound 3: the middle estimate sits 2.0-fold (0.30 log units) below what was measured; the measured number falls inside the stated range.
By their numbers in this assay, from the lowest: compounds 2 and 1 (each within the scatter of the next); then compound 3.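

In this assay, the saturated ring carbon proves to be a position where the read-out responds beyond the scatter once the whole aryl group goes, with a 3.3-fold higher number from compound 2 to compound 3 (0.52 log units; beyond the scatter) and a 2.7-fold higher number from compound 1 to compound 3 (0.43 log units; beyond the scatter). A chloro on that aryl ring had left compound 1 and compound 2 indistinguishable, whereas replacing either 3-chlorophenyl or phenyl with hydrogen gives a higher number, so among these compounds the aryl group at this carbon matters more than the chloro on it. No evidence here explains this shift.

As far as these compounds go, it remains open whether any group at this carbon would keep the lower numbers, or whether that takes an aromatic ring, as a methyl or a cyclohexyl group could show. From the compounds shown here alone, how an amine or a carboxylic acid on the aryl ring would move the number also stays open.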